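Step from compound 2 to compound 4 in this series

The source may report more compounds than this note shows. Statements on the series, on what has been measured and on what is new or still open speak of the compounds shown alone.

Measured so far:
compound 1 `CC(C)n1ncc2c(C(=O)Nc3ccccc3)cccc21`: 19700 nM
compound 2 `CC(C)n1ncc2c(C(=O)NCc3cn(-c4ccccc4)nn3)cccc21`: > 40000 nM
compound 3 `CC(C)n1ncc2c(C(=O)NCc3cn(-c4ccc(I)cc4)nn3)cccc21`: > 40000 nM

In a functional assay on MCF7 cells (Homo sapiens) for inhibition, read by MTT assay, with a stated time of 72 h (on this read-out higher numbers stand for weaker inhibition and lower numbers for stronger inhibition), compound 1 gives 19700 nM. Compound 2 reaches only a limit of this assay, > 40000 nM. Compound 3 likewise stands at a limit, > 40000 nM. The step that the two limits leave unreadable from compound 2 to compound 3 is therefore of unreadable size; the limit of > 40000 nM in this assay, at which 2 of the 3 values shown sit, marks where both of these values rest. Compound 4 `CC(C)n1ncc2c(C(=O)NCc3cn(-c4ccc([N+](=O)[O-])cc4)nn3)cccc21` differs from compound 2 by nitro in place of hydrogen on an aromatic carbon. Among the compounds with values here, the only measured step at this position is the one from compound 2 to compound 3, and since its size cannot be read, no direction can be drawn from it. Compound 4 is expected to sit at or beyond the same limit, the step that the limit leaves unreadable from compound 2 to compound 4 being estimated as nothing readable beyond the scatter. The estimate for compound 4 is 45000 nM, range 20000 nM to 100000 nM.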

Compound 4, half-maximal inhibitory concentration: > 40000 nM
Compound 4: only a limit was reported; the forecaster's own chance of this, stated with the estimate: 85%; the middle value does not contradict the limit.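

Compound 4 stands at a limit, > 40000 nM, and its steps from compound 2 and from compound 3 cannot be read: the limit of > 40000 nM in this assay, at which 3 of the 4 values shown sit.

Going by these compounds, whether iodo or nitro in place of hydrogen on the phenyl ring changes inhibition at all remains open.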